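A few compounds are considered here, and "the series" means these few. Any claim that something is new, unique, unknown or untested is made for them only; others in the source may bear on it.

In an ADME assay on HepG2 cells (Homo sapiens) for cytotoxicity, in the presence of a further agent that is not named here (on this read-out higher numbers stand for weaker inhibition and lower numbers for stronger inhibition), compound 1 (`Cn1c(Cc2ccccc2C(F)(F)F)nc(C(=O)NCc2cccnc2)c(O)c1=O`) gives > 100000 nM as a limit of the assay, not a number. Compound 2 (`CN(Cc1ccccc1)C(=O)c1nc(Cc2ccccc2C(F)(F)F)n(C)c(=O)c1O`) gives > 100000 nM as a limit of the assay too, again not a number. Within the data shown here, compound 2 therefore stands at the limit of > 100000 nM in this assay, at which 2 of the 2 values shown sit, and has no number of its own, and the only other value beside it is likewise a limit. Among the measured compounds shown here, the one measured step is a step that the two limits leave unreadable from compound 1 to compound 2 and it offers no size to carry forward. Compound 3 (`Cn1c(Cc2ccccc2C(F)(F)F)nc(C(=O)NCC2CCCCC2)c(O)c1=O`) shares the core of compound 2 and differs from it in a single place, as follows: (cyclohexylmethyl)amino in place of benzyl(methyl)amino on a carbonyl carbon and in short, (cyclohexylmethyl)amino stands in place of benzyl(methyl)amino on a carbonyl carbon. With both readings at the limit, no step beyond the scatter is expected in this assay and the reading is expected to remain a limit. The estimated step is a number no higher from compound 2 to compound 3 (the limit leaves the size open) and no larger. For compound 3 the expected value is 100000 nM with an estimated range from 40000 nM to 200000 nM in repeated measurements.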

Compound 3, half-maximal inhibitory concentration: > 100000 nM
Compound 3: no number, only a limit; the forecaster's own chance of this, stated with the estimate: 80%; the middle value sits exactly at the limit.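

In this assay, compound 3 gives a limit and not a number, as do compound 1 and compound 2, so no step among these three compounds can be read: the limit of > 100000 nM in this assay, at which 3 of the 3 values shown sit. The compounds shown leave open whether any of these groups on the carbonyl carbon shifts the read-out at all.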